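Isosorbide diester series: aryl ester to nitrooxyalkyl ester

The source may report more compounds than this note shows. Statements on the series, on what has been measured and on what is new or still open speak of the compounds shown alone.

Compound 2 `COc1ccccc1C(=O)O[C@@H]1CO[C@H]2[C@@H]1OC[C@@H]2OC(=O)c1ccccc1OC(C)=O` is the reference point; in an ADME assay on a cell-free system (plasma, Homo sapiens) for metabolic stability, with Plasma (Rattus norvegicus) as the target, read by HPLC, at pH 7.4 (on this read-out lower numbers stand for a shorter-lived compound and higher numbers for a longer-lived compound), compound 2 gives 0.0165 h, and compound 1 `CC(=O)Oc1ccccc1C(=O)O[C@H]1CO[C@H]2[C@@H]1OC[C@H]2OC(=O)c1cccc(O)c1` sits within the scatter of it, since in this assay compound 1 gives 0.015 h. Within the data shown here, the only step measured at the same carbonyl carbon, a 1.1-fold higher number from compound 1 to compound 2 (0.04 log units; within the scatter), changed nothing beyond the scatter. Compound 3 `CC(=O)Oc1ccccc1C(=O)O[C@H]1CO[C@H]2[C@@H]1OC[C@H]2OC(=O)CCO[N+](=O)[O-]` differs from compound 2 by 2-(nitrooxy)ethyl in place of 2-methoxyphenyl on a carbonyl carbon. Among the measured compounds shown here, no measured step replaces an aromatic group by a chain at this position, so the expectation rests on the single flat step and the shared core. For compound 3 the expected step is a 1.1-fold higher number from compound 2 to compound 3 (0.04 log units; within the scatter), within the scatter. Compound 3 is therefore estimated at 0.018 h, ranging from 0.007 h to 0.05 h.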

Compound 3, half-life: 0.0217 h
For compound 3 the middle estimate is 1.2-fold (0.08 log units) below the measured one; measured number inside the range.
By their numbers in this assay, from the lowest: compounds 1, 2 and 3 (each within the scatter of the next).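

In this assay, a chain on this carbonyl carbon reads like an aromatic group, the first such replacement in the series: a 1.3-fold higher number from compound 2 to compound 3 (0.12 log units; within the scatter), and a 1.4-fold higher number from compound 1 to compound 3 (0.16 log units; within the scatter). Both steps lie within the scatter, so across compounds 1, 2 and 3 the half-life does not depend on an aromatic ring at this place. No supporting data bear on the reason for this flatness. As far as these compounds go, whether an amine, a carboxylic acid or a longer chain on this carbonyl carbon would move the half-life beyond the scatter remains open.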